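The source may report more compounds than this note shows. Statements on the series, on what has been measured and on what is new or still open speak of the compounds shown alone.

Measured in a functional assay on RS4-11 cells (Homo sapiens) for inhibition, read by CCK-8 assay, with a stated time of 48 h, tested at 20 uM; on this read-out lower numbers stand for less inhibition of growth and higher numbers for more inhibition of growth at the one concentration tested:
- Compound 1 `Cc1ccc(S(=O)(=O)Oc2ccccc2/C=C(\C#N)C(=O)Nc2nnc(Cc3ccc(F)cc3)s2)cc1`: 72%
- Compound 2 `COc1ccc(S(=O)(=O)Oc2ccccc2/C=C(\C#N)C(=O)Nc2nnc(Cc3ccc(F)cc3)s2)cc1`: 76%
- Compound 3 `N#C/C(=C\c1ccccc1OS(=O)(=O)c1ccc(F)cc1)C(=O)Nc1nnc(Cc2ccc(F)cc2)s1`: 59%

Compound 3 stands lowest of the three at 59%, and its gaps to both others lie beyond the scatter. Compound 4 `Cc1ccc(Cc2nnc(NC(=O)/C(C#N)=C/c3ccccc3OS(=O)(=O)c3ccc(F)cc3)s2)cc1` differs from compound 3 in one place, where 4-fluorobenzyl becomes 4-methylbenzyl: methyl in place of fluoro on an aromatic carbon.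

The closest evidence is a number 13 percentage points lower from compound 1 to compound 3 (beyond the scatter), a modest step with the same two groups exchanged in the opposite sense. The step of a number 17 percentage points lower from compound 2 to compound 3 (beyond the scatter) also brings in fluoro, but it replaces methoxy. Both steps occur on another aromatic ring, however, and the 4-fluorobenzyl group stays the same across compounds 1, 2 and 3. Within the data shown here, no measured step therefore tests this exact place, and only part of the earlier size is expected to carry over. A small rise, within the scatter, is the expectation: a number 6 percentage points higher from compound 3 to compound 4 (within the scatter). Compound 4 is estimated at 65%, with an expected range from 50% to 80%.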

Compound 4, percent growth inhibition at one concentration: 73%
For compound 4 the middle estimate is 8 percentage points below the measured one; low and high end bracket the measured number.
By their numbers in this assay, from the lowest: compound 3; then compounds 1, 4 and 2 (each within the scatter of the next).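

The 4-fluorobenzyl group, held fixed across compounds 1, 2 and 3, proves not to be a silent place: in this assay, 4-methylbenzyl in its stead gives a number 14 percentage points higher from compound 3 to compound 4 (beyond the scatter). The same exchange on the other aromatic ring, read in the opposite sense, gives a number 13 percentage points lower from compound 1 to compound 3 (beyond the scatter), so in both pairs shown the fluoro compound has the lower number, on either ring and by a similar size. Nothing shown accounts for why the methyl compound gives more inhibition of growth at this place.

The compounds shown leave open how other groups at this place, such as an amine, a carboxylic acid or a longer chain, would read. They also leave open whether 4-methylphenyl on the sulfonate side and 4-methylbenzyl together would add up.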